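The source may report more compounds than this note shows. Statements on the series, on what has been measured and on what is new or still open speak of the compounds shown alone.

In a functional assay on QGY-7703 cells (Homo sapiens) for cytotoxicity, read by MTT assay, with a stated time of 24 h (on this read-out higher numbers stand for weaker inhibition and lower numbers for stronger inhibition), compound 1 `O=C1/C(=C/c2ccncc2)CN(S(=O)(=O)c2ccc([N+](=O)[O-])cc2)C/C1=C\c1ccccc1F` gives 8800 nM and compound 2 `O=C1/C(=C/c2ccncc2)CN(S(=O)(=O)c2ccc(F)cc2)C/C1=C\c1ccccc1F` gives 9100 nM on the same shared core. These two numbers lie within the usual scatter of each other, so compound 2 stands level with compound 1 on the evidence so far.

Compound 3 `O=C1/C(=C/c2ccncc2)CN(S(=O)(=O)c2ccc(Br)cc2)C/C1=C\c1ccccc1F` has not yet been measured. It differs from compound 2 at a single place, counted as bromo in place of fluoro on an aromatic carbon in the comparison of the two structures: bromo in place of fluoro on an aromatic carbon, para to a large group, so that 4-fluorophenyl becomes 4-bromophenyl.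

Within the data shown here, one measured step bears on this place, namely a 1.0-fold higher number from compound 1 to compound 2 (0.01 log units; within the scatter) when fluoro stands in place of nitro, and that step lies within the scatter. Among the measured compounds shown here, no compound with bromo has been measured yet, so this single step is thin evidence, but it gives no ground to expect a real shift in this assay for compound 3. The estimated change is a 1.1-fold lower number from compound 2 to compound 3 (0.03 log units; within the scatter) and stays within the scatter. For compound 3 the expected value is 8500 nM with an estimated range from 4500 nM to 15000 nM across repeated measurements.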

Compound 3, half-maximal inhibitory concentration: 11500 nM
The estimate for compound 3 lay 1.4-fold (0.13 log units) below the measured number, and the stated range covers the measured number.
By their numbers in this assay, from the lowest: compounds 1, 2 and 3 (each within the scatter of the next).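

Bromo on this aromatic carbon, para to a large group, fits with the two groups already seen there in this assay: replacing fluoro gives a 1.3-fold higher number from compound 2 to compound 3 (0.10 log units; within the scatter), and replacing nitro gives a 1.3-fold higher number from compound 1 to compound 3 (0.12 log units; within the scatter). Where the earlier compounds offered only one comparison, there are now three groups at this place, nitro, fluoro and bromo, and no pair among compounds 1, 2 and 3 can be told apart, so in these three compounds the choice among them makes no measurable difference to the read-out. Nothing available here explains why the three numbers stay so close together.

The compounds shown leave open whether this place would stay as undemanding with a group of another kind, such as an amine, a carboxylic acid or a longer chain, or with no substituent at all on the ring. They also leave open whether changes elsewhere on the shared core, which stays the same in all three compounds, would move the number beyond the scatter.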